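This account rests on a few compounds, and the source may have more. Where it says the series, first, only, none or still open, it means among the compounds named here.

Measured in an ADME assay on a cell-free system (plasma, Homo sapiens) for metabolic stability, read by LC-MS; on this read-out higher numbers stand for a longer-lived compound and lower numbers for a shorter-lived compound:
- compound 1 `CC(C)OCCOC(=O)c1cccc(-c2cc(C(=O)Nc3ccncc3F)ccc2CN)c1`: 0.1 h
- compound 2 `COC(=O)c1cccc(-c2cc(C(=O)Nc3ccncc3F)ccc2CN)c1`: 1.08 h

Of these two, compound 2 holds the higher number, at 1.08 h. Compound 3 `NCc1ccc(C(=O)Nc2ccncc2F)cc1-c1cccc(C(=O)OCC2CCCC2)c1` is still unmeasured and differs from compound 2 in one place: cyclopentyl in place of hydrogen on a saturated chain carbon bound to an oxygen next to a carbonyl group. In other words, methoxycarbonyl becomes cyclopentylmethoxycarbonyl.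

Going by the values given here, only one measured step bears on this change. an 11-fold higher number from compound 1 to compound 2 (1.03 log units; beyond the scatter) is a large step at the same place, where hydrogen replaces isopropoxymethyl. The new change runs the opposite way, with a group replacing hydrogen, although that group is a different one. A single step is thin support, so a clear fall in this assay is expected, and its size remains uncertain. The estimated step is a 3.6-fold lower number from compound 2 to compound 3 (0.56 log units; beyond the scatter). For compound 3 the expected half-life is 0.3 h, with an estimated range of 0.08 h to 0.9 h.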

Compound 3, half-life: 0.283 h
For compound 3 the middle estimate is 1.1-fold (0.03 log units) above the measured one, and the stated range covers the measured number.
By their numbers in this assay, from the lowest: compound 1; then compound 3; then compound 2.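

In this assay, cyclopentyl in place of hydrogen on a saturated chain carbon bound to an oxygen next to a carbonyl group gives a 3.8-fold lower number from compound 2 to compound 3 (0.58 log units; beyond the scatter), so a second group, one of carbon only, also goes with a shorter half-life than hydrogen at this place. The fall seen earlier with isopropoxymethyl is thus not confined to that one group. The two groups are still not interchangeable: cyclopentyl in place of isopropoxymethyl gives a 2.8-fold higher number from compound 1 to compound 3 (0.45 log units; beyond the scatter), so the size of the fall depends on the group that enters, and nothing given here accounts for the difference.

The compounds shown leave open how an amine, a carboxylic acid or a longer carbon chain at this place would behave in this assay. They also leave open whether the same order of groups would hold with any change elsewhere on the core.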